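The source may hold more compounds than are shown below. What is called first, only, known or untested is meant among the compounds shown, and "the series" means these compounds.

In a functional assay on RS4-11 cells (Homo sapiens) for inhibition, read by CCK-8 assay, with a stated time of 48 h, tested at 20 uM (a higher number here means more inhibition of growth at the concentration tested, a lower number less inhibition of growth), compound 1 `N#C/C(=C\c1ccccc1OS(=O)(=O)c1ccc([N+](=O)[O-])cc1)C(=O)Nc1nnc(Cc2ccc(F)cc2)s1` gives 55% of inhibition, compound 2 `N#C/C(=C\c1ccccc1OS(=O)(=O)c1ccccc1[N+](=O)[O-])C(=O)Nc1nnc(Cc2ccc(F)cc2)s1` gives 61% and compound 3 `N#C/C(=C\c1ccccc1OS(=O)(=O)c1ccc(Cl)cc1)C(=O)Nc1nnc(Cc2ccc(F)cc2)s1` reaches 68% in the same test. Compound 1 thus matches compound 2 within the scatter and stands clearly under compound 3 alone. Compound 4 `Cc1ccc(Cc2nnc(NC(=O)/C(C#N)=C/c3ccccc3OS(=O)(=O)c3ccc([N+](=O)[O-])cc3)s2)cc1` still awaits measurement. It differs from compound 1 by methyl in place of fluoro on an aromatic carbon in one place: methyl in place of fluoro on an aromatic carbon, which turns 4-fluorobenzyl into 4-methylbenzyl. The measured steps all concern the group on the sulfonyl sulfur, showing a number 6 percentage points higher from compound 1 to compound 2 (within the scatter) and a number 7 percentage points higher from compound 2 to compound 3 (within the scatter) and also a number 13 percentage points higher from compound 1 to compound 3 (beyond the scatter) in the largest case. None of them touches the 4-fluorobenzyl group, so they give only a rough sense of how far one small swap can move these compounds. No step beyond the scatter is therefore expected in this assay for this change. The estimated step is a number 1 percentage points higher from compound 1 to compound 4 (within the scatter) as a best guess. For compound 4 the expected value is 56% with an estimated range from 43% to 69% overall.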

Compound 4, percent growth inhibition at one concentration: 64%
Compound 4: the middle estimate sits 8 percentage points below what was measured, within the range that was stated.
By their numbers in this assay, from the lowest: compounds 1, 2, 4 and 3 (each within the scatter of the next, the first and the last beyond it).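

Compound 4 is the first compound shown that changes the 4-fluorobenzyl end rather than the group on the sulfonyl sulfur, and in this assay the swap to 4-methylbenzyl gives a number 9 percentage points higher from compound 1 to compound 4 (within the scatter) within this series. At this place, on an aromatic carbon para to a large group, methyl in place of fluoro therefore produces no change that can be told from the usual scatter, so this one swap is tolerated in compound 1. No measurement shown here bears on the reason for this result.

Only fluoro and methyl appear at this position, so an amine, a carboxylic acid or a longer chain such as propyl there remains an open question. Also open, as far as these compounds go, is whether the same swap would behave alike with the 4-chlorophenyl group of compound 3 on the sulfonyl sulfur.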